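Changing the Group on a Sulfonyl Sulfur

The compounds below may be only part of what the source reports. "The series", "measured", "known", "first", "only" and "open" are said of these compounds alone.

In a functional assay on VCaP cells (Homo sapiens) for antiproliferative activity, read by propidium iodide staining, with a stated time of 96 h (a lower number here means a stronger inhibitor, a higher number a weaker inhibitor), compound 3 `CC(O)(CS(=O)(=O)c1ccccc1C(F)(F)F)C(=O)Nc1ccc(S(F)(F)(F)(F)F)cc1` gives 23800 nM. This lies within the scatter of compound 1 `CC(O)(CS(=O)(=O)c1cccc(S(F)(F)(F)(F)F)c1)C(=O)Nc1ccc(S(F)(F)(F)(F)F)cc1` at 24800 nM, and also of compound 2 `CC(O)(CS(=O)(=O)c1ccc(F)cc1)C(=O)Nc1ccc(S(F)(F)(F)(F)F)cc1` at 34200 nM, so these three values cannot be ranked. Compound 4 `CC(O)(CS(=O)(=O)c1cccc(OC(F)(F)F)c1)C(=O)Nc1ccc(S(F)(F)(F)(F)F)cc1` carries 3-(trifluoromethoxy)phenyl in place of 2-(trifluoromethyl)phenyl on a sulfonyl sulfur. Among the measured compounds shown here, the one measured single-place step that bears on this change, a 1.4-fold lower number from compound 2 to compound 3 (0.16 log units; within the scatter), also replaces the group on that sulfur, and it stays within the scatter. On that evidence, no change beyond the scatter is expected in this assay, and no direction can be favoured. The expected step is a 1.1-fold higher number from compound 3 to compound 4 (0.02 log units; within the scatter). For compound 4 the estimated value is 25000 nM, with an expected range of 14000 nM to 45000 nM.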

Compound 4, half-maximal inhibitory concentration: 23700 nM
Beside the measured number, compound 4's estimate is 1.1-fold (0.02 log units) above it; low and high end bracket the measured number.
By their numbers in this assay, from the lowest: compounds 4, 3, 1 and 2 (each within the scatter of the next).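

In this assay, 3-(trifluoromethoxy)phenyl brings an oxygen and a hydrogen-bond acceptor to the sulfonyl sulfur, yet a 1.0-fold lower number from compound 3 to compound 4 (0.00 log units; within the scatter) and a 1.4-fold lower number from compound 2 to compound 4 (0.16 log units; within the scatter) both stay within the scatter. Changing only the group on the aromatic carbon of that ring, with a 1.0-fold lower number from compound 1 to compound 4 (0.02 log units; within the scatter), also stays within it. Across these compounds, the differences among the substituted phenyl groups on this sulfur therefore cannot be told apart in this assay, and no measurement here explains why. Still open, as far as these compounds go, is whether a simple methyl or longer alkyl chain on the sulfur, or a phenyl ring bearing an amine or a carboxylic acid, would move the number beyond the scatter.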